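Methoxy for methyl on the cyclopropyl-bearing chain

The source may hold more compounds than are shown below. What is called first, only, known or untested is meant among the compounds shown, and "the series" means these compounds.

Compound 2 `CCC(C1CC1)n1nc(C)nc(Nc2ccc(OC)nc2C(F)(F)F)c1=O` gives 3.7 nM in an assay on isolated protein for displacement of a labelled ligand from corticotropin-releasing factor receptor 1 (Rattus norvegicus) (on this read-out lower numbers stand for stronger inhibition and higher numbers for weaker inhibition), the lowest of the two numbers shown; compound 1 `COCC(C1CC1)n1nc(C)nc(Nc2c(Cl)cc(OC(F)(F)F)cc2Cl)c1=O` gives 11 nM in this assay, a gap beyond the scatter, though the two structures also differ elsewhere, so no single step links them. Compound 3 `COCC(C1CC1)n1nc(C)nc(Nc2ccc(OC)nc2C(F)(F)F)c1=O` is not yet measured; it differs from compound 2 by methoxy in place of methyl on a saturated chain carbon, two bonds along the chain from an aromatic nitrogen and a saturated ring carbon. For the measured compounds named here, no measured pair shows this change on its own. The step from compound 2 to compound 3 in this assay is expected to be small, a 1.5-fold higher number from compound 2 to compound 3 (0.17 log units; within the scatter), with no direction settled beyond the scatter. Compound 3 is estimated at 5.5 nM, within 2 nM to 16 nM.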

Compound 3, half-maximal inhibitory concentration: 3.7 nM
Compound 3: middle estimate off by 1.5-fold (0.17 log units), on the high side, and the stated range covers the measured number.
By their numbers in this assay, from the lowest: compounds 2 and 3 (each within the scatter of the next); then compound 1.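

Methoxy in place of methyl on this saturated chain carbon can now be read on its own: in this assay the step is no change at the digits printed from compound 2 to compound 3 (within the scatter), so this position accepts the change on the core of compound 2 without a shift beyond the scatter. No evidence on hand bears on this result. As far as these compounds go, whether the change reads the same on the core of compound 1 remains open. So does the outcome with ethoxy, hydroxyl or an amine on this chain carbon.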